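From ethoxy to butyl on a carbonyl carbon

This account rests on a few compounds, and the source may have more. Where it says the series, first, only, none or still open, it means among the compounds named here.

Measured so far in an ADME assay on HEK-293T cells (Homo sapiens) for cytotoxicity, read by luminescence, with a stated time of 24 h; on this read-out higher numbers stand for lower toxicity in this test and lower numbers for higher toxicity in this test:
Compound 1 `CCCNC(=O)c1cc2sccc2n1Cc1ccc(OC)cc1` gives > 100000 nM as a limit of the assay
Compound 2 `COc1ccc(Cn2c(C(=O)N3CCNCC3)cc3sccc32)cc1` gives > 100000 nM as a limit of the assay
Compound 3 `CCOC(=O)C1CCN(C(=O)c2cc3sccc3n2Cc2ccc(OC)cc2)CC1` gives 39000 nM as a number

Within the data shown here, compound 3 holds the only number. What compound 1 and compound 2 share is the limit of > 100000 nM in this assay, at which 2 of the 3 values shown sit, and no number can be taken from either.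

Compound 4 `CCCCC(=O)C1CCN(C(=O)c2cc3sccc3n2Cc2ccc(OC)cc2)CC1` keeps the rest of compound 3 and carries butyl in place of ethoxy on a carbonyl carbon, the counted difference being butyl in place of ethoxy on a carbonyl carbon and the shared core staying as it is.

Among the measured compounds shown here, the one measured step is a step that the two limits leave unreadable from compound 1 to compound 2 and it concerns piperazin-1-yl in place of propylamino on a carbonyl carbon, not the ethoxy of compound 3. For the measured compounds named here, it offers no size to carry over, and no measured step involves ethoxy or butyl. No change beyond the usual scatter is therefore expected in this assay in either direction.

The expectation rests on compound 3 at 39000 nM alone. The expected change is a 1.1-fold lower number from compound 3 to compound 4 (0.05 log units; within the scatter) on this estimate. For compound 4 the estimated value is 35000 nM with an expected range between 15000 nM and 80000 nM on the same estimate.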

Compound 4, half-maximal cytotoxic concentration: 38900 nM
Estimate against measurement, compound 4: 1.1-fold (0.05 log units) below, within the range that was stated.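

In this assay, among these compounds, butyl in place of ethoxy gives a 1.0-fold lower number from compound 3 to compound 4 (0.00 log units; within the scatter), the only step that can be given a size. On a carbonyl carbon whose other neighbours are a saturated ring carbon, ethoxycarbonyl can thus give way to butylcarbonyl, losing the oxygen and the hydrogen-bond acceptor counted for ethoxy, while the two compounds stay within the scatter of each other on this read-out. The earlier compounds could not show this, as the step from compound 1 to compound 2 cannot be read and only compound 3 and compound 4 carry numbers: the limit of > 100000 nM in this assay, at which 2 of the 4 values shown sit.

The compounds shown leave open whether an amine or a carboxylic acid on this carbonyl carbon, or a chain longer than butyl, would stay level with compound 3 and compound 4 in this assay. They also leave open whether butyl in place of ethoxy would read the same way on a carbonyl carbon with other neighbours.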